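The source may report more compounds than this note shows. Statements on the series, on what has been measured and on what is new or still open speak of the compounds shown alone.

Compound 1 `O=c1[nH]c2ccc(Cl)cc2c(-c2ccccc2Cl)c1CCO` carries a hydroxymethyl chain on the shared core, and in an ADME assay on HepG2 2.2.15 cells (Homo sapiens) for cytotoxicity (on this read-out higher numbers stand for lower toxicity in this test and lower numbers for higher toxicity in this test), compound 1 gives 380000 nM. Compound 2 `O=CCc1c(-c2ccccc2Cl)c2cc(Cl)ccc2[nH]c1=O` has formyl in its place; in this assay compound 2 gives 120000 nM. Compound 3 `CC(=O)NCC(=O)OCCc1c(-c2ccccc2Cl)c2cc(Cl)ccc2[nH]c1=O` carries (acetamidomethyl)carbonyl on the chain oxygen, and in this assay compound 3 gives 110000 nM, the lowest of the three numbers, though compound 2 stands within the scatter of it and only compound 1 lies beyond. The measured steps read: a 3.2-fold lower number from compound 1 to compound 2 (0.50 log units; beyond the scatter); a 3.5-fold lower number from compound 1 to compound 3 (0.54 log units; beyond the scatter); a 1.1-fold lower number from compound 2 to compound 3 (0.04 log units; within the scatter).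

Compound 4 `O=C(OCCc1c(-c2ccccc2Cl)c2cc(Cl)ccc2[nH]c1=O)c1ccco1` differs from compound 3 at the carbonyl carbon: furan-2-yl in place of acetamidomethyl on a carbonyl carbon. For the measured compounds named here, no measured step alters what sits on this carbonyl carbon, so the only guides are the step that brought in the carbonyl group, a 3.5-fold lower number from compound 1 to compound 3 (0.54 log units; beyond the scatter), which was modest, and a 1.1-fold lower number from compound 2 to compound 3 (0.04 log units; within the scatter), which stayed within the scatter. Neither acetamidomethyl nor furan-2-yl is varied anywhere else in the set. The expectation is therefore a step of no clear size in this assay, a 1.2-fold lower number from compound 3 to compound 4 (0.09 log units; within the scatter), in no settled direction. Compound 4 is estimated at 90000 nM in this assay, with a range from 35000 nM to 250000 nM.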

Compound 4, half-maximal cytotoxic concentration: 98000 nM
Compound 4: the middle estimate sits 1.1-fold (0.04 log units) below what was measured; the range from low to high includes it.
By their numbers in this assay, from the lowest: compounds 4, 3 and 2 (each within the scatter of the next); then compound 1.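

Working notes on the series: the first variation on the carbonyl carbon shows that, in this assay, a ring-free group can give way to a five-membered aromatic ring without leaving the scatter, a 1.1-fold lower number from compound 3 to compound 4 (0.05 log units; within the scatter). The second ester also stands within the scatter of the formyl compound, a 1.2-fold lower number from compound 2 to compound 4 (0.09 log units; within the scatter), and beyond the scatter of the compound with the hydrogen on the chain oxygen, a 3.9-fold lower number from compound 1 to compound 4 (0.59 log units; beyond the scatter), so both esters, compound 3 and compound 4, now lie on the lower side of compound 1, as does the non-ester compound 2. No evidence on the cause of these steps is at hand.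

From the compounds shown here alone, whether an amine or a carboxylic acid carried on this carbonyl carbon, or a longer chain in place of acetamidomethyl, would also stay within the scatter of compound 3 and compound 4 remains open. Also open, going by these compounds, is whether the chain oxygen needs the carbonyl group at all, since a methyl ether or an amide linkage in place of the ester could separate the part played by the acyl group from that of the link.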